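Swapping a ring for a smaller amine on the shared core

This account rests on a few compounds, and the source may have more. Where it says the series, first, only, none or still open, it means among the compounds named here.

Of the compounds shown here, two have been measured in a functional assay on MCF7 cells (Homo sapiens) for cytotoxicity, read by sulforhodamine B assay, with a stated time of 48 h; on this read-out higher numbers stand for weaker inhibition of growth and lower numbers for stronger inhibition of growth. Compound 1 `Cc1ccc2nc(/N=C3\C(=O)N(CN4CCCCC4)c4ccccc43)sc2c1` gives 37800 nM, the lower of the two numbers and so the stronger growth inhibitor. Compound 2 `O=C1C(=O)N(CN(c2ccccc2)c2ccccc2)c2cccc(Br)c21` gives 110000 nM, a gap from compound 1 that lies beyond the usual scatter; the two structures differ in several places at once, so no single change can be read from this pair.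

Compound 3 `Cc1ccc2nc(/N=C3\C(=O)N(CN(C)C)c4ccccc43)sc2c1` is not yet measured. It differs from compound 1 in one place: dimethylamino in place of piperidin-1-yl on a saturated chain carbon bound to an amide-type nitrogen in a ring. Going by the values given here, no measured pair shows what such a change does on this core, so nothing here speaks for a large step in either direction. The change is expected to move the number little, as a 1.2-fold higher number from compound 1 to compound 3 (0.08 log units; within the scatter), within or close to the scatter. Compound 3 is therefore estimated at 45000 nM, with a range from 15000 nM to 130000 nM.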

Compound 3, concentration for 50% growth inhibition: 29200 nM
Estimate against measurement, compound 3: 1.5-fold (0.19 log units) above, within the range that was stated.
By their numbers in this assay, from the lowest: compounds 3 and 1 (each within the scatter of the next); then compound 2.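

Going by these compounds alone, this is the first pair that differs in one place only, so in this assay the change from (piperidin-1-yl)methyl to (dimethylamino)methyl can be read on its own (a 1.3-fold lower number from compound 1 to compound 3 (0.11 log units; within the scatter)). At this saturated chain carbon bound to an amide-type nitrogen in a ring, the six-membered ring can give way to dimethylamino, which has no ring, and the two compounds cannot be told apart on this read-out. Nothing available explains why the two groups read alike.

From the compounds shown here alone, it remains open whether other amines at this place, such as morpholin-4-yl or pyrrolidin-1-yl, would also read alike. Also open, going by these compounds, is what happens if a plain hydrogen replaces the whole (dimethylamino)methyl group, which would test whether any amine is needed here.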